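Silyl ether in place of formate on a weak core

This account rests on a few compounds, and the source may have more. Where it says the series, first, only, none or still open, it means among the compounds named here.

Measured so far in a functional assay on MCF7 cells (Homo sapiens) for cytotoxicity, read by sulforhodamine B assay; a lower number here means a stronger inhibitor, a higher number a weaker inhibitor:
Compound 1, `C=C1[C@@H](OC(C)=O)C[C@@H]2[C@](C)(COC=O)[C@H](OC(C)=O)CC[C@@]2(C)[C@@H]1C[C@@H](Nc1ccc(Br)cc1)C1=CCOC1=O`, gives 11400 nM.
Compound 2, `C=C1[C@@H](OC(C)=O)C[C@@H]2[C@](C)(COC=O)[C@H](OC(C)=O)CC[C@@]2(C)[C@@H]1C[C@@H](Nc1ccc(OC)c(OC)c1)C1=CCOC1=O`, gives > 50000 nM, which is a limit of this assay and not a number.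
Compound 3, `C=C1[C@@H](OC(C)=O)C[C@@H]2[C@](C)(COC=O)[C@H](OC(C)=O)CC[C@@]2(C)[C@@H]1C[C@@H](Nc1ccc(OC)cc1)C1=CCOC1=O`, gives 24200 nM.

Compound 2 stands at the weak end of the three: its result is only a limit, as the limit of > 50000 nM in this assay, at which 1 of the 3 values shown sits, records. Compound 4, `C=C1[C@@H](OC(C)=O)C[C@@H]2[C@](C)(CO[Si](C)(C)C(C)(C)C)[C@H](OC(C)=O)CC[C@@]2(C)[C@@H]1C[C@@H](Nc1ccc(OC)c(OC)c1)C1=CCOC1=O`, differs from compound 2 only on the oxygen on a saturated carbon, where (a group of 7 heavy atoms (6 carbon, 1 silicon; no ring) in place of a group of 2 heavy atoms (1 carbon, 1 oxygen; no ring), on an oxygen on a saturated carbon). Among the measured compounds shown here, none of the measured steps touches this place. The steps of an at least 4.3-fold higher number from compound 1 to compound 2 (0.64 log units; beyond the scatter), a 2.1-fold higher number from compound 1 to compound 3 (0.33 log units; beyond the scatter) and an at least 2.0-fold lower number from compound 2 to compound 3 (0.31 log units; beyond the scatter) all concern the aryl group on the amine nitrogen, while the oxygen on the saturated carbon carries the same formyl group in compound 1, compound 2 and compound 3. The data therefore give no measured guide to the size or direction of the step in this assay for a change at that oxygen.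

With compound 2 already at the limit, compound 4 is expected to remain weak, and the step that the limit leaves unreadable from compound 2 to compound 4 is expected to stay within the scatter. Compound 4 is estimated at 60000 nM, in the range 20000 nM to 200000 nM, most likely reported as a limit again.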

Compound 4, half-maximal inhibitory concentration: 4310 nM
Beside the measured number, compound 4's estimate is 14-fold (1.14 log units) above it; the whole stated range lies above it.
By their numbers in this assay, from the lowest: compound 4; then compound 1; then compound 3. At a limit, above all of these: compound 2.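

Among the compounds shown here, compound 4 gives the first reading at the oxygen on a saturated carbon, a place that no earlier step touched, and it shows that this assay responds to a change there: swapping the formyl group for the silyl ether, a group of 7 heavy atoms (6 carbon, 1 silicon), gives an at least 11-fold lower number from compound 2 to compound 4 (1.06 log units; beyond the scatter). For the compounds shown here, the earlier steps all concerned the aryl group on the amine nitrogen, so this is the first sign that the far end of the shared core matters as well. The size of this step is only a bound, as compound 2 has a limit and not a number: the limit of > 50000 nM in this assay, at which 1 of the 4 values shown sits.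

The compounds shown leave open how a free hydroxyl or a methyl ether on that oxygen would read, and without these the step cannot be assigned to the loss of the formyl group or to the arrival of the silyl ether. They also leave open whether the same change would give a similar step with the 4-bromophenyl or 4-methoxyphenyl group on the amine nitrogen.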